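Pyrazole aryl swap: acetamidophenyl to chloromethylphenyl

This account rests on a few compounds, and the source may have more. Where it says the series, first, only, none or still open, it means among the compounds named here.

Compound 1 `CC(=O)Nc1ccc(-c2c(C)nn(-c3nc(-c4ccc(Cl)c(Cl)c4)c(SC(C)C)s3)c2C(=O)O)cc1` is the weakest point among the numbers at hand: in a functional assay on BJAB cells (Homo sapiens) for antiproliferative activity, with a stated time of 4 days (a lower number here means that less compound is needed, a higher number that more compound is needed for the effect), compound 1 gives 139000 nM, the highest of the two reported numbers. Compound 3 `Cc1c(-c2cc(Cl)cc(Cl)c2)c(C(=O)O)nn1-c1nc(-c2cc(Cl)ccc2F)c(SC(C)C)s1`, which carries a 3,5-dichlorophenyl on the pyrazole and a different aryl on the thiazole, gives 4800 nM in this assay, a gap to compound 1 that lies well beyond the scatter. Compound 2 `Cc1c(-c2cc(Cl)cc(Cl)c2)c(C(=O)O)nn1-c1nc(-c2ccc3nccn3c2)c(SC(C)C)s1` is recorded as "not active" (no number reported), without a number.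

Compound 4 `Cc1cc(Cl)cc(-c2c(C)nn(-c3nc(-c4ccc(Cl)c(Cl)c4)c(SC(C)C)s3)c2C(=O)O)c1` differs from compound 1 in one place: 3-chloro-5-methylphenyl in place of 4-acetamidophenyl on an aromatic carbon. Among the compounds with values here, no measured pair shows this exact change. Within the data shown here, the only guidance is that a 3,5-disubstituted halogenated phenyl on the pyrazole accompanies the lower number of compound 3, while compound 2, with the same phenyl, is inactive, so the aryl on the thiazole also matters.

For compound 4 a lower number than compound 1 is expected, the step of a 9.3-fold lower number from compound 1 to compound 4 (0.97 log units; beyond the scatter) being the estimate, because compound 3 reaches 4800 nM with a related phenyl. The estimate for compound 4 in this assay is 15000 nM, with a range from 3000 nM to 70000 nM.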

Compound 4, half-maximal effective concentration: 663 nM
Compound 4: middle estimate off by 23-fold (1.35 log units), on the high side, outside the stated range (below it).
By their numbers in this assay, from the lowest: compound 4; then compound 3; then compound 1.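

In this assay, the aryl at this position on the shared core proves decisive, with a 210-fold lower number from compound 1 to compound 4 (2.32 log units; beyond the scatter) for 3-chloro-5-methylphenyl in place of 4-acetamidophenyl, all else unchanged. Within the data shown here, the earlier compounds offered no one-place comparison, so this is the first direct reading of the position, and it shows that the size of the response to this change is large. No measurement at hand bears on what lies behind the step.

The compounds shown do not separate the loss of the acetamido group from the gain of chlorine and methyl, and a plain phenyl, or a phenyl carrying only chlorine or only methyl, would be needed to divide the step. Also open, as far as these compounds go, is how an amine or a nitrile on the phenyl would compare at this position.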